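The source may report more compounds than this note shows. Statements on the series, on what has been measured and on what is new or still open speak of the compounds shown alone.

Measured compounds:
compound 1, `COc1ccc(C2CC(=NOC(=O)c3ccc(Cl)cc3)CC(c3ccc(OC)cc3)N2C)cc1`, 135000 nM in a functional assay, with a stated time of 30 min; a higher number here means a weaker inhibitor, a lower number a stronger inhibitor
compound 2, `COc1ccc(C2CC(=NOC(=O)c3cccc(Cl)c3)CC(c3ccc(OC)cc3)N2C)cc1`, 136000 nM
compound 3, `COc1ccc(C2CC(=NOC(=O)c3ccccc3O)CC(c3ccc(OC)cc3)N2C)cc1`, 29000 nM

Compound 2 stands highest of the three numbers in this assay, though its step to compound 1, a 1.0-fold higher number from compound 1 to compound 2 (0.00 log units; within the scatter), lies within the scatter, so the two cannot be ordered; the only clear gap is to compound 3, a 4.7-fold lower number from compound 2 to compound 3 (0.67 log units; beyond the scatter).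

Compound 4, `COc1ccc(C2CC(=NOC(=O)c3cc(O)c(O)c(O)c3)CC(c3ccc(OC)cc3)N2C)cc1`, has not yet been measured. It differs from compound 2 in one place: 3,4,5-trihydroxyphenyl in place of 3-chlorophenyl on a carbonyl carbon.

Within the data shown here, no measured step is an exact match for this change. The closest bearing is a 4.7-fold lower number from compound 2 to compound 3 (0.67 log units; beyond the scatter), where a hydroxyl-bearing phenyl replaced the chlorophenyl on the carbonyl carbon and gave a modest drop; a 4.7-fold lower number from compound 1 to compound 3 (0.67 log units; beyond the scatter) is the same change from the other chlorophenyl and reads the same. a 1.0-fold higher number from compound 1 to compound 2 (0.00 log units; within the scatter) shows the chlorine's position made no difference beyond the scatter. Compound 4 carries three hydroxyls where compound 3 carries one, so a step at least as large as a 4.7-fold lower number from compound 2 to compound 3 (0.67 log units; beyond the scatter), and in the same direction, is expected, written as a 5.4-fold lower number from compound 2 to compound 4 (0.74 log units; beyond the scatter). The estimate for compound 4 is therefore 25000 nM, with a range from 8000 nM to 80000 nM.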

Compound 4, half-maximal inhibitory concentration: 18000 nM
For compound 4 the middle estimate is 1.4-fold (0.14 log units) above the measured one; the measured number falls inside the stated range.
By their numbers in this assay, from the lowest: compounds 4 and 3 (each within the scatter of the next); then compounds 1 and 2 (each within the scatter of the next).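

In this assay, 3,4,5-trihydroxyphenyl in place of 3-chlorophenyl on the carbonyl carbon gives a 7.6-fold lower number from compound 2 to compound 4 (0.88 log units; beyond the scatter) and, in place of 4-chlorophenyl, gives a 7.5-fold lower number from compound 1 to compound 4 (0.88 log units; beyond the scatter); the drop seen with the 2-hydroxyphenyl is thus not confined to that one group, since a second hydroxyl-bearing phenyl also separates from both chlorophenyl compounds beyond the scatter. The comparison of the two hydroxyl-bearing phenyls, a 1.6-fold lower number from compound 3 to compound 4 (0.21 log units; within the scatter), lies within the scatter, so these two compounds cannot be ordered and the added hydroxyls bring no readable change over the 2-hydroxyphenyl. Nothing measured here speaks to what lies behind these steps.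

The compounds shown leave open whether the hydroxyl groups themselves matter, as the unsubstituted phenyl and the 3,4,5-trimethoxyphenyl, which would separate the hydroxyl from the ring pattern, do not appear among them. Nor do they show how an aminophenyl or a carboxyphenyl on the same carbonyl carbon would read, or whether any group here can move the number much further than the hydroxyl-bearing phenyls do.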